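Swapping Chloro for Fluoro on a Weak Pair

A few compounds are considered here, and "the series" means these few. Any claim that something is new, unique, unknown or untested is made for them only; others in the source may bear on it.

Compound 1, `CC1CCN(S(=O)(=O)N2CCN(CC(=O)Nc3cccc(Cl)c3)CC2)CC1`: 7600 nM
Compound 2, `CC1CCN(S(=O)(=O)N2CCN(CC(=O)Nc3ccc(Cl)cc3)CC2)CC1`: > 10000 nM
Compound 3, `CC1CCN(S(=O)(=O)N2CCN(CC(=O)Nc3ccc(F)cc3)CC2)CC1`: not yet measured

All three compounds share one core and differ only in the ring carried by the amide-type nitrogen. In an assay on HEK293 cells for activation of potassium channel subfamily T member 1 (Homo sapiens), read by thallium flux (on this read-out higher numbers stand for an effect only at larger amounts of compound and lower numbers for an effect already at smaller amounts), compound 1 gives 7600 nM. For compound 2 the assay reports a limit rather than a number, > 10000 nM, which is the limit of > 10000 nM in this assay, at which 1 of the 2 values shown sits. Going by the values given here, the one measured step, an at least 1.3-fold higher number from compound 1 to compound 2 (0.11 log units; that floor lies within the scatter), moves the chlorine from 3-chlorophenyl to 4-chlorophenyl, so compound 2 stands at the floor of what has been seen here.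

The change to compound 3 is fluoro in place of chloro on an aromatic carbon. Among the compounds with values here, no measured step exchanges one halogen for another; the single step available concerns where the halogen sits, not which halogen it is, so it gives no direct guide. With compound 2 already at the limit, compound 3 is expected to stay weak as well, and an estimate of 15000 nM with a range of 6000 nM to 40000 nM seems reasonable. This expected step, a step that the limit leaves unreadable from compound 2 to compound 3, would most likely again end as a limit.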

Compound 3, half-maximal effective concentration: > 10000 nM
Compound 3 gave a limit, no number; the forecaster's own chance of this, stated with the estimate: 70%; the middle value lies beyond the limit too.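

Compound 3 ends at a limit, > 10000 nM, so in this assay fluoro on this ring, like chloro in compound 2, gives no readable number. Going by these compounds alone, the step between the two halogens cannot be read, as both ends are limits, which leaves the comparison with compound 1 as the only readable step: an at least 1.3-fold higher number from compound 1 to compound 3 (0.11 log units; that floor lies within the scatter). What the new compound adds is that changing the halogen on the 4-substituted phenyl ring does not lift the result off the limit, and 4-chlorophenyl and 4-fluorophenyl now sit together there: the limit of > 10000 nM in this assay, at which 2 of the 3 values shown sit.

Still open, on these data alone, is whether a group of another kind at this place, such as methoxy or an amine, would bring a measurable number, and how far apart compound 2 and compound 3 really lie. Also open is whether 3-fluorophenyl would behave like the 3-chlorophenyl of compound 1, which gives 7600 nM, the only true number among the compounds shown.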